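Replacing oxolan-3-yl with methyl on compound 2

The compounds below may be only part of what the source reports. "The series", "measured", "known", "first", "only" and "open" are said of these compounds alone.

In a functional assay on MCF7 cells (Homo sapiens) for cytotoxicity, read by MTT assay, with a stated time of 72 h (on this read-out higher numbers stand for weaker inhibition and lower numbers for stronger inhibition), compound 1 `O=C(/C=C/c1cccc(Cl)c1Cl)Nc1cc2c(Nc3ccc(F)c(Cl)c3)ncnc2cc1O[C@H]1CCOC1` gives 30100 nM and compound 2 `COc1cc(/C=C/C(=O)Nc2cc3c(Nc4ccc(F)c(Cl)c4)ncnc3cc2O[C@H]2CCOC2)cc(OC)c1OC` gives 28400 nM. The two stand level: the measured change is a 1.1-fold lower number from compound 1 to compound 2 (0.03 log units; within the scatter), so compound 2 cannot be told apart from compound 1. Compound 3 `COc1cc2ncnc(Nc3ccc(F)c(Cl)c3)c2cc1NC(=O)/C=C/c1cc(OC)c(OC)c(OC)c1` differs from compound 2 in a single place: methyl in place of oxolan-3-yl on an oxygen on an aromatic ring. Put simply, it carries methyl in place of oxolan-3-yl on an oxygen on an aromatic ring. Among the measured compounds shown here, the one measured step lies elsewhere in the molecule, so it does not test this swap directly, and no compound measured so far shows what a change at this oxygen does. With compound 2 at 28400 nM as the starting point, no step beyond the scatter is expected in this assay. The expected change is a 1.1-fold lower number from compound 2 to compound 3 (0.06 log units; within the scatter). For compound 3 the estimated value is 25000 nM, with an expected range from 9000 nM to 60000 nM.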

Compound 3, half-maximal inhibitory concentration: "not active" (no number reported)
Nothing numeric was reported for compound 3; the estimate stays without a comparison.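

In this assay, among the compounds shown here, compound 3 is reported only as "not active", with no number, so no step from compound 2 to compound 3 can be read. Nothing shown here bears on this result. The compounds shown leave open how large an effect replacing oxolan-3-yl with methyl has on this oxygen.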